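Sulfonamide aryl variation on a benzoxazole series against HSP60/HSP10

The source may report more compounds than this note shows. Statements on the series, on what has been measured and on what is new or still open speak of the compounds shown alone.

Notes on the series. Going by the values given here, compound 1 `O=S(=O)(Nc1ccc2oc(-c3ccccc3)nc2c1)c1ccc(O)cc1` is the only member with a numerical read-out: in an assay on cells for inhibition of HSP60/HSP10 (Homo sapiens), with a stated time of 60 min (a lower number here means a stronger inhibitor, a higher number a weaker inhibitor), compound 1 gives 88000 nM. Compound 2 `C=Cc1ccc(S(=O)(=O)Nc2ccc3oc(-c4ccccc4)nc3c2)cc1` reaches only the limit of the assay, in this assay compound 2 gives > 100000 nM. Compound 3 `COc1cccc(S(=O)(=O)Nc2ccc3oc(-c4ccccc4)nc3c2)c1` likewise sits at a limit, and in this assay compound 3 gives > 100000 nM. Two of the three values shown therefore rest on (the limit of > 100000 nM in this assay, at which 2 of the 3 values shown sit). Among the compounds with values here, the steps from the one number are small and bounded: an at least 1.1-fold higher number from compound 1 to compound 2 (0.05 log units; that floor lies within the scatter) and an at least 1.1-fold higher number from compound 1 to compound 3 (0.05 log units; that floor lies within the scatter), while a step that the two limits leave unreadable from compound 2 to compound 3. Compound 3 thus stands at the weak end of what the assay can report, with no number of its own.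

Compound 4 `Cc1ccc(S(=O)(=O)Nc2ccc3oc(-c4ccccc4)nc3c2)cc1` is the next step from compound 3: 4-methylphenyl in place of 3-methoxyphenyl on a sulfonyl sulfur. Within the data shown here, no measured step exchanges one substituted phenyl for another between two numerical values, so the size cannot be read from this series; the two bounded steps from compound 1 give no sign of a change beyond the scatter. The expectation for this assay is that compound 4 stays at or near the limit, the estimated step being a number no higher from compound 3 to compound 4 (the limit leaves the size open). The estimate for compound 4 is 100000 nM, within 40000 nM to 300000 nM.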

Compound 4, half-maximal inhibitory concentration: > 100000 nM
Compound 4: a limit, no number; the forecaster's own chance of this, stated with the estimate: 70%; the middle value lies on the limit itself.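

Exchanging the 3-methoxyphenyl, with its hydrogen-bond acceptor, for the 4-methylphenyl, with none, still gives no number in this assay, so a third aryl group on the sulfonyl sulfur now rests on the same limit: the limit of > 100000 nM in this assay, at which 3 of the 4 values shown sit.

The one readable comparison is an at least 1.1-fold higher number from compound 1 to compound 4 (0.05 log units; that floor lies within the scatter), so swapping the hydroxy for a methyl on an aromatic carbon is not shown to change the read-out beyond the scatter. The steps to compound 4 from compound 2 and from compound 3 cannot be read, as both ends of each are limits.

From the compounds shown here alone, how far compound 2, compound 3 and compound 4 lie past the limit, and whether they differ from one another, stays open. Also open, going by these compounds, is whether an amine or a carboxylic acid on that aromatic carbon would move the read-out away from compound 1, at 88000 nM.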